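The source may report more compounds than this note shows. Statements on the series, on what has been measured and on what is new or still open speak of the compounds shown alone.

Measured so far:
- compound 1, `Cc1ccc(-c2cc(/N=C3/NC(=O)CS3)cs2)cc1`: > 50000 nM in a functional assay on HCT-116 cells (Homo sapiens) for cytotoxicity, read by MTT assay, with a stated time of 72 h; on this read-out lower numbers stand for stronger inhibition and higher numbers for weaker inhibition
- compound 2, `COc1ccc(-c2cc(/N=C3/NC(=O)CS3)cs2)cc1`: > 50000 nM
- compound 3, `Cc1ccc(/C=C2\S/C(=N\c3nc(-c4ccc(Cl)cc4)cs3)NC2=O)cc1`: 500 nM

Compound 3 is the only one of the three with a number, and it is a clear one in this assay. The value of compound 1 in this assay is a limit of the assay and not a number. The value of compound 2 is likewise a limit. Between compound 1 and compound 3 the difference between the two cores is not broken down here.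

Compound 1 and compound 2 differ by methoxy in place of methyl on an aromatic carbon. The step that the two limits leave unreadable from compound 1 to compound 2 is left unreadable, because both compounds sit at the same limit, (the limit of > 50000 nM in this assay, at which 2 of the 3 values shown sit), so the two limits say nothing about whether methoxy in place of methyl helps or hurts.

Compound 4, `COc1ccc(/C=C2\S/C(=N\c3nc(-c4ccc(Cl)cc4)cs3)NC2=O)cc1`, has not yet been measured. It differs from compound 3 by methoxy in place of methyl on an aromatic carbon. Cut one bond further out, this reads 4-methylphenyl to 4-methoxyphenyl, and it is the same kind of change as that from compound 1 to compound 2, made this time on the core of compound 3, which already gives a number in this assay.

Going by the values given here, since the only measured example of this change tells nothing, the expectation for compound 4 can rest only on compound 3 and its value of 500 nM, with a step that is expected to be small. The step from compound 3 to compound 4 is estimated as a 1.2-fold higher number from compound 3 to compound 4 (0.08 log units; within the scatter). Compound 4 is therefore expected to give about 600 nM in this assay, somewhere between 200 nM and 2000 nM.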

Compound 4, half-maximal inhibitory concentration: 400 nM
For compound 4 the middle estimate is 1.5-fold (0.18 log units) above the measured one, within the range that was stated.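

Putting methoxy in place of methyl on the core of compound 3 gives a 1.3-fold lower number from compound 3 to compound 4 (0.10 log units; within the scatter) in this assay, so on this core the change has no effect that can be told apart from the ordinary spread of repeated measurements. The same change on the core of compound 1 cannot be read, because compound 1 and compound 2 both carry a limit of the assay and not a number: the limit of > 50000 nM in this assay, at which 2 of the 4 values shown sit. This leaves a single readable example of the change, so the result describes the core of compound 3 and does not show that the change behaves the same way on the core of compound 1 or on any other core.

Among the compounds shown, only methyl and methoxy occupy this place on the core of compound 3, so it remains open how an amine, a carboxylic acid or a longer chain such as ethoxy would behave there. Also open, going by these compounds, is what a different group would do in place of the chlorine, which stays the same in compound 3 and compound 4, and which of the several differences between the two cores matters in this assay.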